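This account rests on a few compounds, and the source may have more. Where it says the series, first, only, none or still open, it means among the compounds named here.

For the measured compounds named here, compound 1 `NC1=NC2(CCSCC2)N(OCCCOc2cccc(Cl)c2Cl)C(N)=N1` has the lowest number of the two compounds measured so far in a functional assay on A549 cells (Homo sapiens) for antiproliferative activity, read by MTT assay, with a stated time of 72 h; a lower number here means a stronger inhibitor, a higher number a weaker inhibitor: compound 1 gives 1 nM. Going by the values given here, the only other measured compound, compound 2 `NC1=NC2(CCOCC2)N(OCCCOc2cccc(Br)c2)C(N)=N1`, gives 160 nM in this assay, a gap well beyond the usual scatter. Compound 2 differs from compound 1 in two places at once, in its core and in its aromatic group, so these two values alone cannot show how much each change contributes. Compound 3 `NC1=NC2(CCSCC2)N(OCCCOc2cccc(Br)c2)C(N)=N1` keeps the core of compound 1 and changes only the aromatic group: 3-bromophenyl in place of 2,3-dichlorophenyl on an oxygen on a saturated carbon. Among the compounds with values here, no single-change step has been measured, so the size of this step is uncertain. Part of the gap to compound 2 may come from the core change, and a loss of potency smaller than that whole gap is expected, a 15-fold higher number from compound 1 to compound 3 (1.18 log units; beyond the scatter). Compound 3 is therefore expected to give about 15 nM in this assay, most likely between 2 nM and 120 nM.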

Compound 3, half-maximal inhibitory concentration: 50 nM
Beside the measured number, compound 3's estimate is 3.3-fold (0.52 log units) below it; low and high end bracket the measured number.
By their numbers in this assay, from the lowest: compound 1; then compound 3; then compound 2.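

In this assay, the aromatic group on the oxygen on a saturated carbon matters on its own: with the core of compound 1 held fixed, 3-bromophenyl in place of 2,3-dichlorophenyl gives a 50-fold higher number from compound 1 to compound 3 (1.70 log units; beyond the scatter). For the compounds shown here, this is the first single-change step, and its size shows that potency at this position depends strongly on which of these two aromatic groups is present. Nothing available here explains why the step is so large.

This step changes both the kind of halogen and the number of halogens on the ring, so it cannot show which of the two drives the loss. As far as these compounds go, how 3-chlorophenyl, 2,3-dibromophenyl or plain phenyl would behave at this position remains open.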